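A few compounds are considered here, and "the series" means these few. Any claim that something is new, unique, unknown or untested is made for them only; others in the source may bear on it.

Compound 1 `Cc1ccc(-c2nn(-c3ccccc3)cc2CNc2ccccc2)cc1` — > 100000 nM
Compound 2 `FC(F)(F)c1ccc(NCc2cn(-c3ccccc3)nc2-c2ccc(Br)cc2)cc1` — 46000 nM

Of the compounds shown here, two have been tested in an ADME assay on MDBK cells (Bos taurus) for cytotoxicity, read by MTT assay, with a stated time of 72 h; a higher number here means that more compound is tolerated, a lower number that less compound is tolerated. For compound 1 the result is a limit of the assay, > 100000 nM, rather than a number. Compound 2 gives 46000 nM in this assay. Among the compounds with values here, this is the only number among the results, since the other result is a limit, as the limit of > 100000 nM in this assay, at which 1 of the 2 values shown sits, shows. Compound 3 `Cc1ccc(-c2nn(-c3ccccc3)cc2CNc2ccc(C(F)(F)F)cc2)cc1` has not yet been measured in this assay. It differs from compound 2 in one place: methyl in place of bromo on an aromatic carbon. Within the data shown here, no step between measured compounds that differ in one place is available, so the size of this change cannot be read from a measured pair. Compound 1, which carries the same methyl group, gives a limit > 100000 nM in this assay. On that ground a small rise in tolerated concentration, perhaps within the scatter, is expected from compound 2 to compound 3, namely a 1.5-fold higher number from compound 2 to compound 3 (0.18 log units; within the scatter). Compound 3 is therefore estimated at 70000 nM, within 30000 nM to 150000 nM.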

Compound 3, half-maximal cytotoxic concentration: > 100000 nM
Compound 3 gave a limit, no number (the forecaster's own chance of this, stated with the estimate: 35%); middle value at least 1.4-fold (0.15 log units) away from the limit.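

In this assay, the change on this aromatic carbon, para to a large group, now has a measured size: methyl in place of bromo gives an at least 2.1-fold higher number from compound 2 to compound 3 (0.33 log units; beyond the scatter). The result for compound 3 is a limit of the assay and not a number, so this step has a floor but no upper end. The step from compound 1 to compound 3, which adds trifluoromethyl in place of hydrogen, cannot be read, as both results are limits: the limit of > 100000 nM in this assay, at which 2 of the 3 values shown sit.

As far as these compounds go, it remains open whether the lower number of compound 2 is particular to bromo, or whether a chloro, methoxy or carboxylic acid group at this position would give a similar number. Also open, from the compounds shown here alone, is whether the trifluoromethyl group has any effect on the tolerated concentration in this assay.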